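A Chain Trimmed Two Bonds from the Ring Oxygen

The source may hold more compounds than are shown below. What is called first, only, known or untested is meant among the compounds shown, and "the series" means these compounds.

Compound 1 `COC(C)(C)CCOc1cccc(OCc2[nH]c3ccccc3c(=O)c2C)c1` has the lower of the two numbers measured in a functional assay on HUVEC cells (Homo sapiens) for inhibition, using NADPH, with a stated time of 2 h (a higher number here means a weaker inhibitor, a lower number a stronger inhibitor), where compound 1 gives 8.3 nM. Among the compounds with values here, the only other measured compound, compound 2 `O=c1cc(COc2cccc(OCC3CCOCC3)c2)[nH]c2ccccc12`, gives 590 nM in this assay, a far higher number that lies well beyond the scatter; since compound 2 differs from compound 1 in more than one place, that gap says nothing by itself about any single change. Compound 3 `CCCCOc1cccc(OCc2[nH]c3ccccc3c(=O)c2C)c1` has not yet been measured. It differs from compound 1 in one place: ethyl in place of 1-methoxy-1-methylethyl on a saturated chain carbon, two bonds along the chain from an oxygen on an aromatic ring. Within the data shown here, no step between measured compounds that differ in one place is available to calibrate this change. The step of a 3.0-fold higher number from compound 1 to compound 3 (0.48 log units; beyond the scatter) is expected to be a modest loss, near the edge of the scatter. Compound 3 is estimated at 25 nM in this assay, with a range from 8 nM to 80 nM.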

Compound 3, half-maximal inhibitory concentration in the HUVEC assay: 4.7 nM
For compound 3 the middle estimate is 5.3-fold (0.73 log units) above the measured one; the whole stated range lies above it.
By their numbers in the HUVEC assay, from the lowest: compounds 3 and 1 (each within the scatter of the next); then compound 2.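

In the HUVEC assay, the exchange of 1-methoxy-1-methylethyl for ethyl on a saturated chain carbon, two bonds along the chain from an oxygen on an aromatic ring, gives a 1.8-fold lower number from compound 1 to compound 3 (0.25 log units; within the scatter), so the plain butoxy chain holds the number reached with 3-methoxy-3-methylbutoxy. In a physicochemical assay for solubility, at pH 6.8 (a higher number here means a more soluble compound, a lower number a less soluble compound), compound 1 gives 2000 nM. In the physicochemical assay compound 3 gives < 1000 nM, which is a limit of the assay and not a number: the limit of < 1000 nM in the physicochemical assay, at which 1 of the 2 values shown sits.

The step between these two compounds in solubility cannot be read from a limit. From the compounds shown here alone, whether a longer chain, or an amine or a carboxylic acid at the end of the chain, would keep the number in the HUVEC assay remains open.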